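Cytotoxicity of two nitroimidazooxazine ethers and a biphenyl analogue

The compounds below may be only part of what the source reports. "The series", "measured", "known", "first", "only" and "open" are said of these compounds alone.

Measured compounds:
compound 1, `O=[N+]([O-])c1cn2c(n1)OC[C@@H](OCc1ccc(-c3ccc(OC(F)(F)F)cc3)c(Cl)c1)C2`, > 128000 nM
compound 2, `O=[N+]([O-])c1cn2c(n1)OCC(COCc1ccc(OCc3ccccc3)cc1)C2`, 113000 nM

In an ADME assay on Vero cells (Chlorocebus sabaeus) for cytotoxicity, with a stated time of 72 h (a lower number here means a stronger inhibitor, a higher number a weaker inhibitor), compound 1 gives > 128000 nM, which is a limit of the assay rather than a number. Within the data shown here, compound 2 is the only compound with a measured number in this assay, and that number, 113000 nM, is the value against which compound 3 must be judged. The value of compound 1 is a limit, as the evidence notes: the limit of > 128000 nM in this assay, at which 1 of the 2 values shown sits.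

Compound 3, `O=[N+]([O-])c1cn2c(n1)OCC(COCc1ccc(-c3ccc(C(F)(F)F)cc3)cc1)C2`, has not been measured. It differs from compound 2 in one place: 4-(trifluoromethyl)phenyl in place of benzyloxy on an aromatic carbon, para to a large group. Among the measured compounds shown here, no measured pair shows a step of this kind, so compound 2 is the only guide. Compound 3 is expected to remain a weak inhibitor in this assay, with the step of a 1.1-fold lower number from compound 2 to compound 3 (0.05 log units; within the scatter) estimated to stay within the scatter of repeated measurements. The estimate for compound 3 is 100000 nM, in the range from 40000 nM to 128000 nM.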

Compound 3, half-maximal inhibitory concentration: 38000 nM
The estimate for compound 3 lay 2.6-fold (0.42 log units) above the measured number, and the stated range ends above it.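

In this assay, this aromatic carbon, para to a large group, proves sensitive to what it carries: 4-(trifluoromethyl)phenyl in place of benzyloxy gives a 3.0-fold lower number from compound 2 to compound 3 (0.47 log units; beyond the scatter). The earlier compounds shown here could not show this, as they offered no step at this position, and the size of this one shows that exchanging one aromatic substituent for another here can move the cytotoxicity read-out beyond the usual scatter. The change takes away the oxygen of benzyloxy and brings in fluorine at once, and nothing measured here explains the shift.

From the compounds shown here alone, whether the shift follows the trifluoromethyl group or the loss of the benzyloxy oxygen remains open, and a plain phenyl at this position would separate the two. Going by these compounds, how an amine or a carboxylic acid on the outer ring would read in this assay also remains open.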